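Chain aryl swaps on the anilide series

The source may hold more compounds than are shown below. What is called first, only, known or untested is meant among the compounds shown, and "the series" means these compounds.

Compound 1 `COc1ccc(C(=O)c2cc(OC)c(OC)c(OC)c2)cc1NC(=O)/C=C/c1ccc(OC)c(OC)c1` gives 10200 nM in a functional assay on DU-145 cells (Homo sapiens) for cytotoxicity, read by MTT assay, with a stated time of 72 h (a higher number here means a weaker inhibitor, a lower number a stronger inhibitor), the lowest of the three numbers, though both neighbours sit within the scatter of it: compound 2 `C#CCOc1cccc(/C=C/C(=O)Nc2cc(C(=O)c3cc(OC)c(OC)c(OC)c3)ccc2OC)c1` gives 15800 nM and compound 3 `COc1cc(/C=C/C(=O)Nc2cc(C(=O)c3cc(OC)c(OC)c(OC)c3)ccc2OC)ccc1F` gives 12100 nM. The step from compound 1 to compound 4 `COc1ccc(C(=O)c2cc(OC)c(OC)c(OC)c2)cc1NC(=O)/C=C/c1ccc(F)c(F)c1` replaces (3,4-difluorophenyl in place of 3,4-dimethoxyphenyl on a double-bonded chain carbon bound to a double-bonded chain carbon). Two measured steps exchange the same aryl on the double-bonded chain carbon: a 1.5-fold higher number from compound 1 to compound 2 (0.19 log units; within the scatter) and a 1.2-fold higher number from compound 1 to compound 3 (0.07 log units; within the scatter), each within the scatter, and a 1.3-fold lower number from compound 2 to compound 3 (0.12 log units; within the scatter) also stays within it. As none of these exchanges moved the number beyond the scatter, no step beyond the scatter is expected for compound 4 either, estimated as a 1.1-fold higher number from compound 1 to compound 4 (0.05 log units; within the scatter). Compound 4 is therefore estimated at 11500 nM, with a range from 5000 nM to 26000 nM.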

Compound 4, half-maximal inhibitory concentration: 10200 nM
The estimate for compound 4 lay 1.1-fold (0.05 log units) above the measured number; measured number inside the range.
By their numbers in this assay, from the lowest: compounds 1, 4, 3 and 2 (each within the scatter of the next).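

Exchanging the 3,4-dimethoxyphenyl for 3,4-difluorophenyl on a double-bonded chain carbon gives no change at the digits printed from compound 1 to compound 4 (within the scatter) in this assay, although the entering aryl carries no oxygen and no hydrogen-bond acceptors. The other two steps, a 1.2-fold lower number from compound 3 to compound 4 (0.07 log units; within the scatter) and a 1.5-fold lower number from compound 2 to compound 4 (0.19 log units; within the scatter), also stay within the scatter, so this position has tolerated an aryl with only fluoro substituents as well as those bearing oxygen. No evidence on hand bears on this result.

Open, on these data alone, is whether any group on this aryl moves the number beyond the scatter. An amine or a carboxylic acid there would test this.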